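The source may hold more compounds than are shown below. What is called first, only, known or untested is meant among the compounds shown, and "the series" means these compounds.

Measured compounds:
compound 1, `CCCCS(=O)(=O)Nc1cc(-c2ccc3ncnc(Nc4ccc(OCCO)nc4)c3c2)cnc1OC`: > 20000 nM
compound 2, `COc1ncc(-c2ccc3ncnc(Nc4ccc(OCCO)c(Cl)c4)c3c2)cc1NS(=O)(=O)c1ccc(F)cc1F`: 3740 nM

Among the measured compounds shown here, in a functional assay on MCF7 cells (Homo sapiens) for antiproliferative activity, read by sulforhodamine B assay, with a stated time of 72 h (a lower number here means a stronger inhibitor, a higher number a weaker inhibitor), compound 2 gives 3740 nM, the only number among the two values shown. For compound 1 the result is a limit, > 20000 nM, as noted in the limit of > 20000 nM in this assay, at which 1 of the 2 values shown sits. Compound 3, `COc1ncc(-c2ccc3ncnc(Nc4ccc(OCCO)nc4)c3c2)cc1NS(=O)(=O)c1ccc(F)cc1F`, is not yet measured in this assay. It differs from compound 2 in one place: 6-(2-hydroxyethoxy)pyridin-3-yl in place of 3-chloro-4-(2-hydroxyethoxy)phenyl on a nitrogen on an aromatic ring. For the measured compounds named here, no pair of measured compounds differing in one place is available, so the size of this step cannot be read from a measured step. Compound 1 carries the same pyridin-3-yl group as compound 3 together with a different sulfonamide, and its value sits at the limit. The expectation for compound 3 is therefore a loss of potency, estimated as a 4.0-fold higher number from compound 2 to compound 3 (0.60 log units; beyond the scatter), beyond the scatter. Compound 3 is expected to give about 15000 nM, within 5000 nM to 40000 nM, with a fair chance that only a limit is reported.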

Compound 3, half-maximal inhibitory concentration: 4300 nM
Compound 3: the middle estimate sits 3.5-fold (0.54 log units) above what was measured, outside the stated range (below it).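

In this assay, replacing 3-chloro-4-(2-hydroxyethoxy)phenyl with 6-(2-hydroxyethoxy)pyridin-3-yl on the nitrogen gives a 1.1-fold higher number from compound 2 to compound 3 (0.06 log units; within the scatter), so the two groups cannot be told apart here. Compound 3 carries the same pyridin-3-yl group as compound 1, which shows that this group is compatible with a measurable value, and the change that separates these two compounds lies on the sulfonyl sulfur, where 2,4-difluorophenyl replaces butyl: an at least 4.6-fold lower number from compound 1 to compound 3 (0.66 log units; beyond the scatter). That step has no fixed size, as compound 1 gives only a limit in this assay: the limit of > 20000 nM in this assay, at which 1 of the 3 values shown sits.

From the compounds shown here alone, the chlorine and the ring nitrogen change together, so what either does alone stays open. Also open, going by these compounds, is whether an amine or a carboxylic acid in place of the hydroxyl of the 2-hydroxyethoxy chain would change the number.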